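Ring in Place of Chain on an Amide-Type Nitrogen Substituent

The compounds below may be only part of what the source reports. "The series", "measured", "known", "first", "only" and "open" are said of these compounds alone.

Compound 1, `CCCCCC(=O)Nc1ccc(S(=O)(=O)Oc2ccccc2I)cc1`: in a functional assay on M21 cells (Homo sapiens) for antiproliferative activity, read by sulforhodamine B assay, with a stated time of 48 h (on this read-out lower numbers stand for stronger inhibition and higher numbers for weaker inhibition), compound 1 gives 11000 nM.
Compound 2, `O=C(CCl)Nc1ccc(S(=O)(=O)Oc2ccccc2I)cc1`: in this assay compound 2 gives 3900 nM.
Compound 3, `CCCNC(=O)Nc1ccc(S(=O)(=O)Oc2ccccc2I)cc1`: in this assay compound 3 gives 5400 nM.

Compound 3 stands second highest of the three numbers. Its nearest neighbour is compound 2, and a 1.4-fold higher number from compound 2 to compound 3 (0.14 log units; within the scatter), which is within the scatter, so no order between the two can be read. Against compound 1 the gap is clearer: a 2.0-fold lower number from compound 1 to compound 3 (0.31 log units; beyond the scatter).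

Compound 4, `O=C(NCC1CCCC1)Nc1ccc(S(=O)(=O)Oc2ccccc2I)cc1`, differs from compound 3 in one place: cyclopentyl in place of ethyl on a saturated chain carbon bound to an amide-type nitrogen. Within the data shown here, no measured step adds a ring anywhere, so the change has no direct precedent. The two steps that alter the group on the carbonyl side, a 2.8-fold lower number from compound 1 to compound 2 (0.45 log units; beyond the scatter) and a 2.0-fold lower number from compound 1 to compound 3 (0.31 log units; beyond the scatter), are both modest, and the one in which propylamino replaces pentyl shows that more carbon at this end of the molecule did not lower the number. A small shift upward, or none beyond the scatter, is the most that can be expected in this assay.

Compound 4 is therefore expected to give 7000 nM, with a range from 2500 nM to 20000 nM. This estimate means an expected 1.3-fold higher number from compound 3 to compound 4 (0.11 log units; within the scatter).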

Compound 4, half-maximal inhibitory concentration: 7600 nM
Compound 4: middle estimate off by 1.1-fold (0.04 log units), on the low side; the measured number falls inside the stated range.
By their numbers in this assay, from the lowest: compounds 2, 3, 4 and 1 (each within the scatter of the next, the first and the last beyond it).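

Among the compounds shown, compound 4 carries the only added ring, and in this assay cyclopentyl in place of ethyl on a saturated chain carbon bound to an amide-type nitrogen gives a 1.4-fold higher number from compound 3 to compound 4 (0.15 log units; within the scatter), so this larger group, five carbons for two, produces no change that can be read. Compound 4 also lies within the scatter of both other compounds, with a 1.9-fold higher number from compound 2 to compound 4 (0.29 log units; within the scatter) and a 1.4-fold lower number from compound 1 to compound 4 (0.16 log units; within the scatter), even though compound 1 and compound 2 are separated by more than the scatter, so it cannot be grouped with either. No separate measurement speaks to what lies behind this result.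

On these data alone, whether cyclohexyl, phenyl, an amine or a carboxylic acid at this place would move the number beyond the scatter stays open. So does whether cyclopentyl bound directly to the amide-type nitrogen would read the same.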